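One Arm Exchanged on a Compound Showing No Inhibition

The compounds below may be only part of what the source reports. "The series", "measured", "known", "first", "only" and "open" are said of these compounds alone.

Compound 2 `Clc1ccc2sc(CN3CCN(c4ncnc5c4CN(Cc4ccccc4)CC5)CC3)cc2c1` and compound 1 `COC[C@@H]1CCCN1C(=O)[C@@H]1CCCN1c1cc(Nc2cccc(OC)c2)nc(N)n1` were both tested in an assay on isolated protein for inhibition of calcium/calmodulin-dependent protein kinase type II subunit alpha (Homo sapiens), read by HTRF, tested at 10 uM; on this read-out higher numbers stand for more inhibition at the one concentration tested (going by the name of the read-out) and lower numbers for less inhibition. In that test compound 1 gives 0%. Compound 2 gives 0%, level with compound 1 at the digits shown and within the scatter of repeated measurements of this kind, so neither shows inhibition at the one concentration tested. Compound 3 `O=C(CN1CCN(c2ncnc3c2CN(Cc2ccccc2)CC3)CC1)Nc1cc(F)ccc1F` has not yet been measured in this assay. It differs from compound 2 in one place: (2,5-difluorophenyl)carbamoyl in place of 5-chloro-1-benzothiophen-2-yl on a saturated chain carbon bound to an amine nitrogen in a ring. Among the measured compounds shown here, no step between two measured compounds differing in a single place is available, so there is nothing to set the size of this change against, and the only guide is the read-out of compound 2 itself. Because compound 2 gives 0%, the expectation is that compound 3 stays close to it, the step being expected as a number 3 percentage points higher from compound 2 to compound 3 (within the scatter), nothing beyond the scatter. Compound 3 is therefore estimated at 3%, with a range from -10% to 20%.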

Compound 3, a percentage reported as inhibition, at one concentration (the size of the read-out at that concentration, not a potency): 0%
Compound 3: the middle estimate sits 3 percentage points above what was measured; measured number inside the range.
By their numbers in this assay, from the lowest: compounds 1, 2 and 3 (each within the scatter of the next).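

In this assay, among the compounds shown here, putting (2,5-difluorophenyl)carbamoyl in place of 5-chloro-1-benzothiophen-2-yl on a saturated chain carbon bound to an amine nitrogen in a ring gives no change at the digits printed from compound 2 to compound 3 (within the scatter), the first step here that can be read at a single place. At this position, then, replacing the two aromatic rings of the leaving group with the single aromatic ring and hydrogen-bond donor of the entering group brings no inhibition into view at the one concentration tested. With both compounds showing no inhibition, the step cannot tell whether the two groups would truly match in a compound that does inhibit, and nothing measured here explains the result.

Going by these compounds, it remains open whether a different group at this position, such as a carboxylic acid or a primary amine on a longer chain, would give any inhibition. On these data alone, it is also open whether any group here can register in this test while the rest of compound 2 stays unchanged.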